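A few compounds are considered here, and "the series" means these few. Any claim that something is new, unique, unknown or untested is made for them only; others in the source may bear on it.

Working notes on the series. Among the measured compounds shown here, compound 1 `ClCc1ccccc1Cn1cnc2c(Cl)nc(Cl)nc21` is the only member with a number in hand: in a functional assay on HOP-92 cells (Homo sapiens) for cytotoxicity, read by sulforhodamine B assay, with a stated time of 48 h (on this read-out lower numbers stand for stronger inhibition of growth and higher numbers for weaker inhibition of growth), compound 1 gives 350 nM. Compound 2 `ClCc1cccc(Cn2cnc3ncnc(Cl)c32)c1` was run in this assay, but in this assay compound 2 gives "not determined" (no result reported), so compound 2 stands nowhere on the scale shown, and there is no step between compound 2 and any other compound to speak of. Compound 3 `ClCc1cccc(Cn2cnc3nc(Cl)nc(Cl)c32)c1` has not yet been measured in this assay. The structural change from compound 2 to compound 3 is chloro in place of hydrogen on an aromatic carbon. For the measured compounds named here, without a value for compound 2 no size of step in this assay can be read from the data; the only anchor is the result of compound 1, which shares the dichloro substitution pattern of compound 3. On that anchor alone compound 3 is expected to give a growth-inhibition concentration near 450 nM, estimated to lie between 100 nM and 2500 nM in this assay.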

Compound 3, concentration for 50% growth inhibition: 1470 nM
Beside the measured number, compound 3's estimate is 3.3-fold (0.51 log units) below it; the range from low to high includes it.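

Among the compounds shown here, with compound 2 carrying no number in this assay, no step from compound 2 to compound 3 can be read. The compounds shown leave open what size of step chloro in place of hydrogen gives in this assay. No supporting evidence bears on this result.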